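Swapping the indane ring for a trifluoromethoxyphenyl

A few compounds are considered here, and "the series" means these few. Any claim that something is new, unique, unknown or untested is made for them only; others in the source may bear on it.

Two compounds have so far been measured in an in vitro assay on BHK cells for binding affinity to gastric inhibitory polypeptide receptor (Homo sapiens); a lower number here means a stronger inhibitor, a higher number a weaker inhibitor:

compound 1, `Cc1cc(N(Cc2ccc(C(=O)NCCC(=O)O)cc2)c2nc(-c3ccc(C(F)(F)F)cc3)cs2)ccc1C(C)C`, 293 nM
compound 2, `O=C(O)CCNC(=O)c1ccc(CN(c2ccc3c(c2)CCC3)c2nc(-c3ccc(C(F)(F)F)cc3)cs2)cc1`, 510 nM

Of the two numbers, that of compound 2 is the larger on paper, yet the step of a 1.7-fold higher number from compound 1 to compound 2 (0.24 log units; within the scatter) lies within the scatter, so no order can be claimed between compound 2 and compound 1. Among the measured compounds shown here, that step exchanges the 4-isopropyl-3-methylphenyl ring on the nitrogen on an aromatic ring for 2,3-dihydro-1H-inden-5-yl and is the only measured change at that position.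

Compound 3, `O=C(O)CCNC(=O)c1ccc(CN(c2ccc(OC(F)(F)F)cc2)c2nc(-c3ccc(C(F)(F)F)cc3)cs2)cc1`, differs from compound 2 in the same place: 4-(trifluoromethoxy)phenyl in place of 2,3-dihydro-1H-inden-5-yl on a nitrogen on an aromatic ring. For the measured compounds named here, the single measured step at this position, a 1.7-fold higher number from compound 1 to compound 2 (0.24 log units; within the scatter), was small, so exchanging one aryl group for another on this nitrogen has so far moved the number little. On that basis the step of a 1.1-fold lower number from compound 2 to compound 3 (0.05 log units; within the scatter) in this assay is expected to stay within the scatter, with no firm direction. Compound 3 is therefore estimated at 450 nM, with a range from 150 nM to 1400 nM.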

Compound 3, half-maximal inhibitory concentration: 480 nM
Estimate against measurement, compound 3: 1.1-fold (0.03 log units) below; low and high end bracket the measured number.
By their numbers in this assay, from the lowest: compounds 1, 3 and 2 (each within the scatter of the next).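

With a third aryl group on this nitrogen, this assay gives two further steps (a 1.1-fold lower number from compound 2 to compound 3 (0.03 log units; within the scatter); a 1.6-fold higher number from compound 1 to compound 3 (0.21 log units; within the scatter)), and both lie within the scatter, so compound 1, compound 2 and compound 3 cannot be put in any order. The new point is that the entering 4-(trifluoromethoxy)phenyl group carries oxygen, fluorine and a hydrogen-bond acceptor, whereas 2,3-dihydro-1H-inden-5-yl and 4-isopropyl-3-methylphenyl are built of carbon only, and yet compound 3 still stands within the scatter of both compound 2 and compound 1. Aryl groups of this wider range of atoms are therefore so far not told apart at this position, and no measurement at hand offers an explanation for this result.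

All three groups on this nitrogen are aryl rings, so the compounds shown leave open whether a group of another kind there, such as a cyclohexyl ring, an amine or a carboxylic acid, would move the number beyond the scatter. As far as these compounds go, the trifluoromethyl group and the carboxylic acid chain are shared by compound 1, compound 2 and compound 3, so how the number responds to a change in either of them also remains open.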